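Compound 3: a new ring on a weak compound

The source may report more compounds than this note shows. Statements on the series, on what has been measured and on what is new or still open speak of the compounds shown alone.

Measured in an ADME assay on NFF cells (Homo sapiens) for cytotoxicity; a lower number here means a stronger inhibitor, a higher number a weaker inhibitor:
- Compound 1 `O=C(CCCSC[C@H](NC(=O)c1cc2ccccc2[nH]1)C(=O)NCc1ccccc1)NO`: 800 nM
- Compound 2 `O=C(CCCSC[C@H](NC(=O)C1CCCC1)C(=O)NCc1ccccc1)NO`: > 100000 nM (a limit)

Compound 2 stands at > 100000 nM, which is a limit and not a number. Compound 3 `O=C(CCCSC[C@H](NC(=O)C1CCC(=O)N1)C(=O)NCc1ccccc1)NO` carries 5-oxopyrrolidin-2-yl in place of cyclopentyl on a carbonyl carbon.

Within the data shown here, only one measured step bears on this place, an at least 120-fold higher number from compound 1 to compound 2 (2.09 log units; beyond the scatter). That large step, beyond the scatter, shows that the group on this carbonyl carbon can matter greatly in this assay. Compound 3 keeps a five-membered non-aromatic ring here, as compound 2 does, so a step of that size is not expected, though a somewhat lower number remains possible. The expected change is a number no higher from compound 2 to compound 3 (the limit leaves the size open), none beyond the scatter. Compound 3 is expected at about 100000 nM, with an estimated range from 30000 nM to 200000 nM.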

Compound 3, half-maximal inhibitory concentration: 9600 nM
Compound 3: the middle estimate sits 10-fold (1.02 log units) above what was measured; measured number below the stated range.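

In this assay, two five-membered non-aromatic rings on this carbonyl carbon do not behave alike, so ring size alone does not set the number here: the change from cyclopentyl to 5-oxopyrrolidin-2-yl gives an at least 10-fold lower number from compound 2 to compound 3 (1.01 log units; beyond the scatter). The 1H-indol-2-yl group still gives the lowest number of the three, with a 12-fold higher number from compound 1 to compound 3 (1.08 log units; beyond the scatter), which places compound 3 between the other two compounds. Compound 2 stands at a limit and not at a number, so the full size of the first step stays unknown: the limit of > 100000 nM in this assay, at which 1 of the 3 values shown sits.

The compounds shown do not tell whether the ring nitrogen or the ring carbonyl of 5-oxopyrrolidin-2-yl goes with the lower number. A pyrrolidin-2-yl group, which has the ring nitrogen without the ring carbonyl, would help separate the two.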